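This account rests on a few compounds, and the source may have more. Where it says the series, first, only, none or still open, it means among the compounds named here.

Working notes on the series. Compound 1 `COc1ccc(-c2cc3c(cn2)[nH]c(=O)n3-c2cc(OC)c(OC)c(OC)c2)cc1` carries a methoxy group on the pendant phenyl ring and gives 840 nM in a functional assay on HCT-116 cells (Homo sapiens) for antiproliferative activity, read by MTT assay, with a stated time of 48 h; on this read-out lower numbers stand for stronger inhibition and higher numbers for weaker inhibition. Compound 2 `CCOc1ccc(-c2cc3c(cn2)[nH]c(=O)n3-c2cc(OC)c(OC)c(OC)c2)cc1` differs from it by methyl in place of hydrogen on a saturated chain carbon bound to an oxygen on an aromatic ring, and in this assay compound 2 gives 6660 nM, so the step of a 7.9-fold higher number from compound 1 to compound 2 (0.90 log units; beyond the scatter). Compound 3 `CCn1c(=O)n(-c2cc(OC)c(OC)c(OC)c2)c2cc(-c3ccc(OC)c(O)c3)ncc21` belongs to a different core; the difference between the two cores is not broken down here. In this assay compound 3 returns only a limit, > 20000 nM, which is the limit of > 20000 nM in this assay, at which 1 of the 3 values shown sits. Compound 4 `COc1ccc(-c2cc3c(cn2)n(C(C)C)c(=O)n3-c2cc(OC)c(OC)c(OC)c2)cc1O` is not yet measured; it differs from compound 3 by methyl in place of hydrogen on a saturated chain carbon bound to an aromatic nitrogen and a saturated chain carbon. This is the same kind of change as that from compound 1 to compound 2, but the place is not the same: there the added methyl sits on a saturated chain carbon bound to an oxygen on an aromatic ring, here on a saturated chain carbon bound to an aromatic nitrogen and a saturated chain carbon. Given that compound 3 already sits at the limit > 20000 nM and that the earlier step of a 7.9-fold higher number from compound 1 to compound 2 (0.90 log units; beyond the scatter) raised the number, compound 4 is expected to remain at or beyond the limit, with the expected step that the limit leaves unreadable from compound 3 to compound 4. The estimate for compound 4 is 35000 nM, with a range from 12000 nM to 100000 nM.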

Compound 4, half-maximal inhibitory concentration: 6660 nM
The estimate for compound 4 lay 5.3-fold (0.72 log units) above the measured number; the whole stated range lies above it.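

In this assay the new step is an at least 3.0-fold lower number from compound 3 to compound 4 (0.47 log units; beyond the scatter), while the earlier one is a 7.9-fold higher number from compound 1 to compound 2 (0.90 log units; beyond the scatter), so the added methyl does not carry a fixed direction from one core to the other: the same change on two cores in this assay, a 7.9-fold higher number (0.90 log units; beyond the scatter) from compound 1 to compound 2 and an at least 3.0-fold lower number (0.47 log units; beyond the scatter) from compound 3 to compound 4, at least 23-fold (1.37 log units) apart, beyond the scatter of two such steps

Compound 3 stands only at a limit, so the new step gives a minimum size and not an exact one: the limit of > 20000 nM in this assay, at which 1 of the 4 values shown sits.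

The two methyl groups also sit in different places, one on a saturated chain carbon bound to an oxygen on an aromatic ring and the other on a saturated chain carbon bound to an aromatic nitrogen and a saturated chain carbon, so this pair of steps does not show whether core or place separates them, and it sets no rule for the series.

The compounds shown leave open whether the same change at the same place gives the same result on both cores. They also leave open how a longer chain, such as butyl, or a chain ending in an amine or a carboxylic acid would read out on the aromatic nitrogen.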